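Furan-2-yl in place of thiophen-3-yl on a nucleoside core

A few compounds are considered here, and "the series" means these few. Any claim that something is new, unique, unknown or untested is made for them only; others in the source may bear on it.

Compound 1 `CNc1ncnc2c1c(-c1ccsc1)cn2[C@@H]1O[C@H](CO)[C@@H](O)[C@H]1O` has a methylamino group on its core. In a functional assay on HCT-116 cells (Homo sapiens), read by MTT assay, with a stated time of 72 h (on this read-out higher numbers stand for weaker inhibition and lower numbers for stronger inhibition), compound 1 gives only a limit, > 20000 nM. Its neighbour compound 2 `CSc1ncnc2c1c(-c1ccsc1)cn2[C@@H]1O[C@H](CO)[C@@H](O)[C@H]1O` carries methylsulfanyl in place of methylamino on an aromatic carbon. In this assay compound 2 likewise gives only a limit, > 20000 nM. The step from compound 1 to compound 2 is therefore a step that the two limits leave unreadable from compound 1 to compound 2, since both values sit at the limit of > 20000 nM in this assay, at which 2 of the 2 values shown sit.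

Compound 3 `CNc1ncnc2c1c(-c1ccco1)cn2[C@@H]1O[C@H](CO)[C@@H](O)[C@H]1O` is not yet measured. It differs from compound 1 by furan-2-yl in place of thiophen-3-yl on an aromatic carbon. Within the data shown here, no measured step touches this position, so the only bearing evidence is that compound 1 sits at a limit, (the limit of > 20000 nM in this assay, at which 2 of the 2 values shown sit). Compound 3 is expected to remain near that limit, with a step that the limit leaves unreadable from compound 1 to compound 3 from compound 1. The estimate for compound 3 in this assay is 30000 nM, within a range from 8000 nM to 120000 nM.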

Compound 3, half-maximal inhibitory concentration: 230 nM
Estimate against measurement, compound 3: 130-fold (2.12 log units) above, outside the stated range (below it).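

The aromatic carbon two ring bonds from the ring nitrogen proves sensitive to its substituent: with the methylamino group held fixed, furan-2-yl in place of thiophen-3-yl gives an at least 86-fold lower number from compound 1 to compound 3 (1.93 log units; beyond the scatter) in this assay. Among these compounds, this is the first readable change here, as the step between compound 1 and compound 2 cannot be read, and it arises between two groups with matching counts of heavy atoms, donors and acceptors. The value of compound 1 is a limit, so the size of this step is only a minimum: the limit of > 20000 nM in this assay, at which 2 of the 3 values shown sit.

The compounds shown do not separate the exchange of sulfur for oxygen from the shift in attachment point, which thiophen-2-yl or furan-3-yl on the same carbon would address. They also leave open why the step occurs and whether methylsulfanyl in place of methylamino would keep the gain with furan-2-yl.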